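Orexin type 2 antagonism: from a pyridine to a fluorophenyl

The source may hold more compounds than are shown below. What is called first, only, known or untested is meant among the compounds shown, and "the series" means these compounds.

Measured compounds:
compound 1 `CCN(CCn1ccc(-c2cc(C(F)(F)F)ccn2)n1)C(=O)c1cc(C)ccc1-n1nccn1` 66.4 nM
compound 2 `CCN(CCn1ccc(-c2cccc(C(F)(F)F)n2)n1)C(=O)c1cc(C)ccc1-n1nccn1` 3.92 nM
compound 3 `CCN(CCn1ccc(-c2cccc(C)n2)n1)C(=O)c1cc(C)ccc1-n1nccn1` 1.96 nM

In a functional assay on CHO cells for antagonist activity at Orexin receptor type 2 (Homo sapiens), read by fluorescence and calcium flux, with a stated time of 30 min (on this read-out lower numbers stand for stronger inhibition and higher numbers for weaker inhibition), compound 2 sits second highest of the three numbers. Its nearest neighbour is compound 3, a 2.0-fold lower number from compound 2 to compound 3 (0.30 log units; within the scatter); its furthest is compound 1, a 17-fold lower number from compound 1 to compound 2 (1.23 log units; beyond the scatter). Compound 4 `CCN(CCn1ccc(-c2ccc(F)cc2)n1)C(=O)c1cc(C)ccc1-n1nccn1` differs from compound 2 by 4-fluorophenyl in place of 6-(trifluoromethyl)pyridin-2-yl on an aromatic carbon. For the measured compounds named here, none of the measured steps changes the ring itself: the steps of a 17-fold lower number from compound 1 to compound 2 (1.23 log units; beyond the scatter) and a 34-fold lower number from compound 1 to compound 3 (1.53 log units; beyond the scatter) move or swap a substituent on the same pyridine, and the step of a 2.0-fold lower number from compound 2 to compound 3 (0.30 log units; within the scatter) swaps one substituent for another. They show that this part of the molecule matters, but give no direction for a ring change. For compound 4 a weaker number is therefore expected, with wide uncertainty, a 7.7-fold higher number from compound 2 to compound 4 (0.88 log units; beyond the scatter), giving an estimate of 30 nM within 5 nM to 200 nM.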

Compound 4, antagonist equilibrium constant: 1.25 nM
Estimate against measurement, compound 4: 24-fold (1.38 log units) above, outside the stated range (below it).
By their numbers in this assay, from the lowest: compounds 4, 3 and 2 (each within the scatter of the next, the first and the last beyond it); then compound 1.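

In this assay a ring of carbon only, with no hydrogen-bond acceptor, serves at this position at least as well as the pyridines, giving a 3.1-fold lower number from compound 2 to compound 4 (0.50 log units; beyond the scatter) and a 53-fold lower number from compound 1 to compound 4 (1.73 log units; beyond the scatter) on the same change. The 6-methylpyridin-2-yl group cannot be told apart from 4-fluorophenyl, with a 1.6-fold lower number from compound 3 to compound 4 (0.20 log units; within the scatter) as the step. Nothing measured here accounts for this tolerance of the ring change. From the compounds shown here alone, whether an amine or a carboxylic acid on the phenyl ring, or a five-membered ring in its place, would keep this activity remains open.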